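This account rests on a few compounds, and the source may have more. Where it says the series, first, only, none or still open, it means among the compounds named here.

Measured so far in an assay on isolated protein for inhibition of ribosomal protein S6 kinase alpha-2 (Homo sapiens), read by fluorescence, with a stated time of 20 min, tested at 10 uM; on this read-out lower numbers stand for less inhibition and higher numbers for more inhibition at the one concentration tested (going by the name of the read-out):

compound 1 `O=C1c2ccccc2C(=O)N1CNc1ccc(Cl)cc1`: 8.52%
compound 2 `Cc1ccc(NCN2C(=O)c3ccccc3C2=O)cc1`: 54%
compound 3 `CC(C)c1ccc(NCN2C(=O)c3ccccc3C2=O)cc1`: 46.5%

Compound 3 holds the second highest of the three numbers. Its nearest neighbour is compound 2, separated by a number 7.5 percentage points lower from compound 2 to compound 3 (within the scatter); the only wide gap is to compound 1, a number 38 percentage points higher from compound 1 to compound 3 (beyond the scatter). Compound 4 `O=C1c2ccccc2C(=O)N1CNc1ccc(OC(F)(F)F)cc1` is not yet measured; it differs from compound 3 by trifluoromethoxy in place of isopropyl on an aromatic carbon.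

The two steps that bear on this change both replace chloro on an aromatic carbon by an alkyl group: a number 45.5 percentage points higher from compound 1 to compound 2 (beyond the scatter) and a number 38 percentage points higher from compound 1 to compound 3 (beyond the scatter). Between the two alkyls the step was a number 7.5 percentage points lower from compound 2 to compound 3 (within the scatter). Among the compounds with values here, no measured step introduces trifluoromethoxy or any group containing oxygen or fluorine at that position, so the direction of the new step rests on little. Within the data shown here, the one non-alkyl group seen there, chloro, sits with the lowest number; on that basis compound 4 is expected to fall below compound 3, the expected step being a number 21.5 percentage points lower from compound 3 to compound 4 (beyond the scatter), though with a wide range. Compound 4 is estimated at 25%, between 5% and 55%.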

Compound 4, a percentage reported as inhibition, at one concentration (the size of the read-out at that concentration, not a potency): 28.1%
Compound 4: the middle estimate sits 3.1 percentage points below what was measured, within the range that was stated.
By their numbers in this assay, from the lowest: compound 1; then compound 4; then compounds 3 and 2 (each within the scatter of the next).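

In this assay, within the data shown here, trifluoromethoxy brings oxygen and fluorine to this aromatic carbon for the first time, and it gives an intermediate result: a number 18.4 percentage points lower from compound 3 to compound 4 (beyond the scatter) and a number 25.9 percentage points lower from compound 2 to compound 4 (beyond the scatter) but a number 19.6 percentage points higher from compound 1 to compound 4 (beyond the scatter) at the same place. The two alkyl compounds therefore both stand above the two compounds with non-alkyl groups, with no exception among these four compounds. Those two non-alkyl groups do not share one level, so leaving the alkyl groups does not lead to a single outcome here, and no available measurement bears on the reason for this order.

As far as these compounds go, how a methoxy, an amine, a carboxylic acid or a longer alkyl chain would compare at this place remains open, as does the standing of the core with hydrogen there. With a single tested concentration, these numbers also leave the potency of all four compounds open.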